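Side-chain amine swap on the dichlorobenzamide quinoline

A few compounds are considered here, and "the series" means these few. Any claim that something is new, unique, unknown or untested is made for them only; others in the source may bear on it.

Working notes on a small set of antiproliferative quinoline amides tested in a functional assay on SK-BR-3 cells (Homo sapiens) for antiproliferative activity, read by MTT assay, with a stated time of 72 h; on this read-out higher numbers stand for weaker inhibition and lower numbers for stronger inhibition. Within the data shown here, compound 1 `Cc1cc(NCCN(C)C)nc2ccc(NC(=O)c3ccc(Cl)c(Cl)c3)cc12` gives 6670 nM and stands second highest of the three numbers so far. Compound 2 `CCN1CCN(c2cc(C)c3cc(NC(=O)c4ccc5ccccc5n4)ccc3n2)CC1` gives 3760 nM, which lies within the scatter of the number for compound 1. Compound 3 `CCN1CCN(c2cc(C)c3cc(NC(=O)c4ccc(F)cc4)ccc3n2)CC1` gives 19800 nM, beyond the scatter from compound 1 and the highest number of the set. Among the measured compounds shown here, the single well-defined step, a 5.3-fold higher number from compound 2 to compound 3 (0.72 log units; beyond the scatter), concerns the aryl group on the carbonyl, not the basic side chain.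

Compound 4 `Cc1cc(NCCN2CCCC2)nc2ccc(NC(=O)c3ccc(Cl)c(Cl)c3)cc12` differs from compound 1 only in that side chain: pyrrolidin-1-yl in place of dimethylamino on a saturated chain carbon, two bonds along the chain from a nitrogen on an aromatic ring. For the measured compounds named here, no measured pair addresses this part of the molecule, so there is nothing to support a step in either direction; the expectation is therefore a number for compound 4 close to that of compound 1, with a 1.1-fold lower number from compound 1 to compound 4 (0.05 log units; within the scatter) estimated to fall within the scatter. Compound 4 is expected at 6000 nM, with a range from 2500 nM to 15000 nM.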

Compound 4, half-maximal inhibitory concentration in the SK-BR-3 assay: 9530 nM
Estimate against measurement, compound 4: 1.6-fold (0.20 log units) below, and the stated range covers the measured number.
By their numbers in the SK-BR-3 assay, from the lowest: compounds 2, 1 and 4 (each within the scatter of the next, the first and the last beyond it); then compound 3.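

Among these compounds, in the SK-BR-3 assay the first measured change in the side chain, pyrrolidin-1-yl in place of dimethylamino, gives a 1.4-fold higher number from compound 1 to compound 4 (0.15 log units; within the scatter) and so leaves compound 4 level with its parent despite the added ring. In a physicochemical assay for solubility (a lower number here means a less soluble compound, a higher number a more soluble compound), compound 1 gives 122 ug/mL and compound 4 gives 84.5 ug/mL and this pair also lies within the scatter, so neither read-out separates the two amines. Nothing at hand accounts for either result.

From the compounds shown here alone, whether a piperidine or a morpholine in place of dimethylamino on the same chain carbon, or a longer chain, would move either number stays open. Steps linking compound 1 or compound 4 to compound 2 or compound 3 cannot be read, as those pairs differ in more than one place.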